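Methoxy for Methyl: Expecting a Small Step in Paw Edema

This account rests on a few compounds, and the source may have more. Where it says the series, first, only, none or still open, it means among the compounds named here.

In a functional assay on the whole organism (strain Wistar albino) for inhibition, with Rattus norvegicus as the target, read by paw edema, with stated times of 1 h and 2 h, at a dose of 0.32 mmol/kg by the intraperitoneal route (on this read-out higher numbers stand for more inhibition at the one dose given (going by the name of the read-out) and lower numbers for less inhibition), two compounds have been measured. Compound 1 `Cc1ccc(-c2nn(-c3ccc(S(N)(=O)=O)cc3)cc2/C=C\C(=O)c2ccc(Cl)cc2)cc1` gives 53.3%. Compound 2 `COc1ccc(-c2[nH]c(-c3ccc(Cl)cc3)cc2-c2cn(-c3ccc(Cl)cc3)nc2-c2ccc(C)cc2)cc1` gives 9.38%, which is the lowest of the two numbers; compound 1 lies well above it, a gap beyond the usual scatter of this kind of measurement. Among the measured compounds shown here, no step between two measured compounds that differ in one place is known, so no directly comparable single change has yet been seen in this assay.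

Compound 3 `COc1ccc(-c2nn(-c3ccc(Cl)cc3)cc2-c2cc(-c3ccc(Cl)cc3)[nH]c2-c2ccc(OC)cc2)cc1` has not been measured. It differs from compound 2 in one place only: methoxy in place of methyl on an aromatic carbon. The change is small in what it counts, a single carbon replaced by a carbon and an oxygen on the outer ring of the shared core.

For the measured compounds named here, with no measured step of this kind to lean on, the step from compound 2 to compound 3 is expected to be small, within the scatter, and in no reliable direction, as a number 2.6 percentage points higher from compound 2 to compound 3 (within the scatter) shows. Compound 3 is accordingly estimated at 12%, with a range from 3% to 25%.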

Compound 3, a percentage reported as inhibition, in the whole organism at one dose (the size of the read-out at that dose, not a potency): 10.5%
Compound 3: the middle estimate sits 1.5 percentage points above what was measured; the measured number falls inside the stated range.
By their numbers in this assay, from the lowest: compounds 2 and 3 (each within the scatter of the next); then compound 1.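

In this assay, among the compounds shown here, this is the first change in a single place that can be read, and it gives a number 1.1 percentage points higher from compound 2 to compound 3 (within the scatter), so compound 2 and compound 3 cannot be told apart. At this position, on a six-membered aromatic ring of carbon only and para to a large group, going from 4-methylphenyl to 4-methoxyphenyl adds one oxygen and one hydrogen-bond acceptor with no visible effect on the read-out at this one dose. Nothing measured here bears on what lies behind this result.

The compounds shown leave open whether a different group at this place, such as an amine, a carboxylic acid or a longer chain like ethoxy, would also leave the number within the scatter or would move it clearly. They also leave open whether methoxy in place of methyl would do as little on the core of compound 1, which carries a methyl-bearing ring of its own, since one step on one core cannot show how the same change behaves elsewhere.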